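Anilide series: chloro to trifluoromethyl at the reading limit

The source may hold more compounds than are shown below. What is called first, only, known or untested is meant among the compounds shown, and "the series" means these compounds.

Compound 1 `CC(C)c1sc(N2CCN(C)CC2)nc1C(=O)Nc1ccc(F)cc1Cl` gives > 100000 nM in an ADME assay on HepG2 cells (Homo sapiens) for inhibition; a higher number here means a weaker inhibitor, a lower number a stronger inhibitor; this value is a limit of the assay.
Compound 2 `CC(C)c1sc(N2CCN(C)CC2)nc1C(=O)Nc1ccccc1Cl` gives > 100000 nM in this assay; this value too is a limit.

Compound 2 therefore stands only at a limit, and the step that the two limits leave unreadable from compound 1 to compound 2 cannot be sized (the limit of > 100000 nM in this assay, at which 2 of the 2 values shown sit). Compound 3 `CC(C)c1sc(N2CCN(C)CC2)nc1C(=O)Nc1ccccc1C(F)(F)F` differs from compound 2 by trifluoromethyl in place of chloro on an aromatic carbon, on an aromatic carbon ortho to a large group. For the measured compounds named here, no measured step bears on this change, so no direction can be read. Compound 3 is expected to sit again at the limit, estimated at 150000 nM (range 50000 nM to 500000 nM), a step that the limit leaves unreadable from compound 2 to compound 3.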

Compound 3, half-maximal inhibitory concentration: 50000 nM
Estimate against measurement, compound 3: 3.0-fold (0.48 log units) above, within the range that was stated.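

Trifluoromethyl in place of chloro on this aromatic carbon, ortho to a large group, gives in this assay an at least 2.0-fold lower number from compound 2 to compound 3 (0.30 log units; that floor lies within the scatter). Compound 3 is the first compound shown to give a number rather than a limit, so a change at this position can register in the assay. The floor of the step is all that can be read, and it does not establish a change beyond the scatter.

From the compounds shown here alone, the true value of compound 2 remains open, and with it the full size of this step. Also open, going by these compounds, is how a methoxy group or an amine on this aromatic carbon would read.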